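Swapping the naphthyl group of compound 2 for bromophenyl

A few compounds are considered here, and "the series" means these few. Any claim that something is new, unique, unknown or untested is made for them only; others in the source may bear on it.

Of the compounds shown here, three sharing one core have been measured in a functional assay on MCF7 cells (Homo sapiens) for inhibition, read by MTT assay, with a stated time of 24 h; on this read-out lower numbers stand for stronger inhibition and higher numbers for weaker inhibition. Compound 1 `CCOC(=O)C1=Cc2ccccc2OC1(OCc1cn(CC(=O)NC2CCCCC2)nn1)C(F)(F)F` gives 12100 nM. Compound 2 `CCOC(=O)C1=Cc2ccccc2OC1(OCc1cc(-c2ccc3ccccc3c2)no1)C(F)(F)F` gives 65400 nM, the higher of the two plain numbers, with compound 1 a clear distance below it. Compound 3 `O=C(O)C1=Cc2ccccc2OC1(OCc1cc(-c2ccc3ccccc3c2)no1)C(F)(F)F` reaches only the limit of the assay, > 150000 nM, so no number is known for it. Within the data shown here, the one measured step between neighbours is an at least 2.2-fold higher number from compound 2 to compound 3 (0.36 log units; beyond the scatter), and it concerns the ester end of the molecule. Because compound 3 sits at the assay's limit of > 150000 nM in this assay, at which 1 of the 3 values shown sits, only a lower bound on that step is known.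

Compound 4 `CCOC(=O)C1=Cc2ccccc2OC1(OCc1cc(-c2ccc(Br)cc2)no1)C(F)(F)F` has not yet been measured. It differs from compound 2 in the group carried by the five-membered ring: 4-bromophenyl in place of naphthalen-2-yl on an aromatic carbon. Among the measured compounds shown here, no measured step touches this position, so the only guide is that compound 2 itself is weak. The change is therefore expected to stay within the scatter, giving a 1.3-fold lower number from compound 2 to compound 4 (0.12 log units; within the scatter). Compound 4 is estimated at 50000 nM, with a likely range from 15000 nM to 150000 nM.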

Compound 4, half-maximal inhibitory concentration: > 150000 nM
Compound 4: no number, only a limit; the forecaster's own chance of this, stated with the estimate: 20%; middle value at least 3.0-fold (0.47 log units) away from the limit.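

Among these compounds, the group carried by the five-membered ring turns out to matter: 4-bromophenyl in place of naphthalen-2-yl gives an at least 2.2-fold higher number from compound 2 to compound 4 (0.36 log units; beyond the scatter) and this is the first measured step at this position. The ester end is therefore not the only place where a single change from compound 2 leads to a weaker result. Compound 4 has no number, only a limit of the assay, so its step is a lower bound: the limit of > 150000 nM in this assay, at which 2 of the 4 values shown sit.

This change swaps two aromatic rings for one and also brings in bromine, and the compounds shown cannot separate these two parts. Going by these compounds, a plain phenyl group or a 4-chlorophenyl group at this position would help to tell them apart, and whether any group here gives a lower number than naphthalen-2-yl remains open.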